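This account rests on a few compounds, and the source may have more. Where it says the series, first, only, none or still open, it means among the compounds named here.

Compound 1 `CCOC(=O)CN(C)C(=O)OCN(c1ccc([N+](=O)[O-])cc1Oc1ccccc1)S(C)(=O)=O` has the higher of the two half-lives recorded here: in an ADME assay on a cell-free system (plasma, Homo sapiens) for metabolic stability (a lower number here means that the compound disappears faster, a higher number that the compound lasts longer), compound 1 gives 49.2 h, whereas compound 2 `Nc1ccc(S(=O)(=O)N(COC(=O)c2ccccc2)c2ncccn2)cc1` in this assay gives 0.023 h, a far shorter survival. Compound 3 `CC(C)(C)C(=O)OCN(c1ccc([N+](=O)[O-])cc1Oc1ccccc1)S(C)(=O)=O` has not yet been measured in this assay. It differs from compound 1 by one change, (tert-butyl in place of ((ethoxycarbonyl)methyl)(methyl)amino on a carbonyl carbon), which turns the carbamate-type linkage into a simple ester. Within the data shown here, with no measured pair of this kind to lean on, a downward step of moderate size, beyond the usual scatter, is expected for a 4.9-fold lower number from compound 1 to compound 3 (0.69 log units; beyond the scatter). Compound 3 is therefore estimated to give 10 h in this assay, with a plausible range from 2 h to 40 h.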

Compound 3, half-life: 1.7 h
The estimate for compound 3 lay 5.9-fold (0.77 log units) above the measured number; measured number outside the range, below it.
By their numbers in this assay, from the lowest: compound 2; then compound 3; then compound 1.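

On this carbonyl carbon, tert-butyl in place of ((ethoxycarbonyl)methyl)(methyl)amino gives a 29-fold lower number from compound 1 to compound 3 (1.46 log units; beyond the scatter) in this assay. This shows that a change at this one place, with the rest of the core unchanged, is enough to shift the half-life well beyond the scatter, which compound 1 and compound 2 could not show, as they differ in more than one place. No available evidence accounts for the step.

As far as these compounds go, it remains open whether the amino nitrogen or the ethoxycarbonyl end of the departing group matters more. A plain dimethylamino group or a carboxylic acid in place of the ethyl ester would help to separate the two.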